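Swapping a Hydroxy for a Methyl on the Aryl Ring

The source may report more compounds than this note shows. Statements on the series, on what has been measured and on what is new or still open speak of the compounds shown alone.

Measured compounds:
compound 1 `Cc1cc(/C=C2\CCCN=C2c2cccnc2)cc(C)c1O` 360 nM
compound 2 `Cc1cc(O)cc(C)c1/C=C1\CCCN=C1c1cccnc1` 670 nM

Compound 2 gives the higher of the two numbers in an assay on membranes from brain for displacement of a labelled ligand from Neuronal acetylcholine receptor; alpha4/beta2 (Rattus norvegicus), with a stated time of 3 h (a lower number here means a stronger inhibitor, a higher number a weaker inhibitor), with compound 1 separated from it by a gap that lies within the scatter. Compound 3 `Cc1cc(C)c(/C=C2\CCCN=C2c2cccnc2)c(C)c1` differs from compound 2 in one place: methyl in place of hydroxy on an aromatic carbon. Going by the values given here, no measured pair traces this change, so the size of the step is uncertain. A small weakening is expected, the step of a 1.9-fold higher number from compound 2 to compound 3 (0.29 log units; within the scatter) at the edge of the scatter. Compound 3 is therefore estimated at 1300 nM in this assay, in a range from 400 nM to 4000 nM.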

Compound 3, inhibition constant: 520 nM
For compound 3 the middle estimate is 2.5-fold (0.40 log units) above the measured one, within the range that was stated.
By their numbers in this assay, from the lowest: compounds 1, 3 and 2 (each within the scatter of the next).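

In this assay, the exchange of hydroxy for methyl on this aromatic carbon, para to a large group, gives a 1.3-fold lower number from compound 2 to compound 3 (0.11 log units; within the scatter). At this position, then, a group counted with a hydrogen-bond donor and acceptor gives way to one counted with neither, and the number stays within the scatter. Nothing given here accounts for this result.

As far as these compounds go, whether an amine, a methoxy group or a carboxylic acid would be accepted at this position stays open. So does whether the same exchange would give a similar step elsewhere on the ring.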